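Swapping an Oxazole for a Pyrazole on a Urea

The source may report more compounds than this note shows. Statements on the series, on what has been measured and on what is new or still open speak of the compounds shown alone.

Compound 1 `CCOC(=O)c1ccc(NC(=O)NCc2cocn2)cc1` was tested in an assay on isolated protein for activation of Nicotinamide phosphoribosyltransferase (Homo sapiens) (on this read-out lower numbers stand for an effect already at smaller amounts and higher numbers for an effect only at larger amounts of compound), where compound 1 gives 27600 nM. Of the two numbers in hand this is the highest: compound 2 `CNS(=O)(=O)c1ccc(NC(=O)NCc2ccncc2)cc1` gives 3230 nM in this assay, and the gap between compound 1 and compound 2 lies beyond the usual scatter. Compound 2 differs from compound 1 in more than one place, so no single change can be read from that pair. Compound 3 `CCOC(=O)c1ccc(NC(=O)NCc2cc[nH]n2)cc1` has not been measured. It differs from compound 1 in one place: 1H-pyrazol-3-yl in place of 1,3-oxazol-4-yl on a saturated chain carbon bound to an amide-type nitrogen. For the measured compounds named here, no measured pair shows what this swap does. Going by the values given here, with only one anchor and no comparable step, the change is expected to amount to a 1.5-fold lower number from compound 1 to compound 3 (0.19 log units; within the scatter), small enough to fall within the scatter, in either direction. Compound 3 is estimated at 18000 nM in this assay, with a range from 5000 nM to 60000 nM.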

Compound 3, half-maximal effective concentration: 69000 nM
Estimate against measurement, compound 3: 3.8-fold (0.58 log units) below, and the stated range ends below it.
By their numbers in this assay, from the lowest: compound 2; then compound 1; then compound 3.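

In this assay the swap to 1H-pyrazol-3-yl on a saturated chain carbon bound to an amide-type nitrogen gives a 2.5-fold higher number from compound 1 to compound 3 (0.40 log units; beyond the scatter) and so moves the effect to larger amounts of compound. This position therefore distinguishes between these two five-membered aromatic rings, even though both have the same number of heavy atoms and differ mainly in their hetero atoms, with a hydrogen-bond donor on the entering ring that the leaving ring lacks. No measurement at hand explains why the ring swap has this effect.

As far as these compounds go, whether that donor hydrogen matters stays open, and a 1-methyl-1H-pyrazol-3-yl group, which has a methyl on that nitrogen instead, would test it. How a 1,3-thiazol-4-yl ring or a longer chain would behave in this place is also unknown.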